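This account rests on a few compounds, and the source may have more. Where it says the series, first, only, none or still open, it means among the compounds named here.

Working notes on the series. Compound 1 `O=c1ccoc2cc(OCc3cn(Cc4cccc(F)c4)nn3)ccc12`, compound 2 `O=c1ccoc2cc(OCc3cn(Cc4cccc([N+](=O)[O-])c4)nn3)ccc12` and compound 3 `O=c1ccoc2cc(OCc3cn(Cc4ccccc4Cl)nn3)ccc12` share one core and differ only in the benzyl group. In a functional assay on QGY7701 cells (Homo sapiens) for cytotoxicity, read by MTT assay, with a stated time of 48 h (a higher number here means a weaker inhibitor, a lower number a stronger inhibitor), compound 2 gives 14100 nM and compound 3 gives 19700 nM. For compound 1 this assay reports only a limit, > 100000 nM. Compound 3 and compound 2 lie within the scatter of each other, a 1.4-fold higher number from compound 2 to compound 3 (0.15 log units; within the scatter), so neither can be placed ahead of the other; the third value is a limit.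

Compound 4 `O=c1ccoc2cc(OCc3cn(Cc4ccccc4F)nn3)ccc12` differs from compound 3 by fluoro in place of chloro on an aromatic carbon. Within the data shown here, no measured step exchanges one halogen for another at the same position. The nearest are an at least 5.0-fold lower number from compound 1 to compound 3 (0.70 log units; beyond the scatter), which moves from a fluorophenyl to a chlorophenyl and is bounded because compound 1 sits at the limit of > 100000 nM in this assay, at which 1 of the 3 values shown sits, and an at least 7.0-fold lower number from compound 1 to compound 2 (0.85 log units; beyond the scatter), where fluoro is again the weaker partner. Returning to fluoro is therefore expected to raise the number, a 2.3-fold higher number from compound 3 to compound 4 (0.36 log units; beyond the scatter), with a real chance of a limit. Compound 4 is expected to give 45000 nM, between 15000 nM and 150000 nM.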

Compound 4, half-maximal inhibitory concentration: 36900 nM
Compound 4: middle estimate off by 1.2-fold (0.09 log units), on the high side; low and high end bracket the measured number.
By their numbers in this assay, from the lowest: compounds 2, 3 and 4 (each within the scatter of the next, the first and the last beyond it). At a limit, above all of these: compound 1.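

In this assay, among these compounds, the first exchange of one halogen for another at the same place, on an aromatic carbon ortho to a large group, gives a 1.9-fold higher number from compound 3 to compound 4 (0.27 log units; within the scatter), so chloro and fluoro cannot be told apart there. The 3-nitrophenyl group is separated from the 2-fluorophenyl group, with a 2.6-fold higher number from compound 2 to compound 4 (0.42 log units; beyond the scatter), although it is not separated from the 2-chlorophenyl group. The 2-fluorophenyl group in place of the 3-fluorophenyl group gives an at least 2.7-fold lower number from compound 1 to compound 4 (0.43 log units; beyond the scatter), so fluoro as such does not hold a compound at a limit, and this step is bounded by compound 1: the limit of > 100000 nM in this assay, at which 1 of the 4 values shown sits.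

On these data alone, the size of that step stays open while one end of it is a limit. Also open, as far as these compounds go, is what bromo, an amine or a carboxylic acid would give at this place on the ring.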